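Dropping One Methyl from the Ketone Aryl of Compound 1

The source may hold more compounds than are shown below. What is called first, only, known or untested is meant among the compounds shown, and "the series" means these compounds.

Compound 1 `COc1cc(-c2cc(/C=C/C(=O)c3ccc(C)c(C)c3)nc3cc(-c4ccccc4)nn23)cc(OC)c1OC` was tested in an ADME assay on HEK293 cells (Homo sapiens) for antiproliferative activity, read by MTT assay, with a stated time of 24 h (on this read-out lower numbers stand for stronger inhibition and higher numbers for weaker inhibition), where compound 1 gives 72500 nM. Within the data shown here, this is the higher of the two numbers so far; the other, compound 2 `COc1ccc(-c2cc(/C=C/C(=O)c3ccc(Cl)cc3)nc3cc(-c4ccccc4)nn23)cc1OC`, gives 44100 nM in this assay, and the two lie within the scatter of each other. Compound 3 `COc1cc(-c2cc(/C=C/C(=O)c3ccc(C)cc3)nc3cc(-c4ccccc4)nn23)cc(OC)c1OC` has not yet been measured. It differs from compound 1 by hydrogen in place of methyl on an aromatic carbon. Among the measured compounds shown here, with no measured step of this kind to lean on, the expected step of a 1.0-fold lower number from compound 1 to compound 3 (0.02 log units; within the scatter) is small, not beyond the scatter in either direction. Compound 3 is therefore expected to give about 70000 nM, within 30000 nM to 160000 nM.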

Compound 3, half-maximal inhibitory concentration: 50400 nM
For compound 3 the middle estimate is 1.4-fold (0.14 log units) above the measured one, and the stated range covers the measured number.
By their numbers in this assay, from the lowest: compounds 2, 3 and 1 (each within the scatter of the next).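

In this assay, replacing 3,4-dimethylphenyl with 4-methylphenyl is a 1.4-fold lower number from compound 1 to compound 3 (0.16 log units; within the scatter). Among these compounds, this is the first single-place comparison, and it shows that the methyl on this aromatic carbon, ortho to a methyl group, can give way to hydrogen without a shift beyond the scatter. Nothing available accounts for this result. Going by these compounds, whether an amine or a carboxylic acid at this carbon would move the number beyond the scatter remains open. So does the effect of changing the remaining 4-methyl group.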